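Chloro to Methoxy: Expecting No Shift in Cytotoxicity

This account rests on a few compounds, and the source may have more. Where it says the series, first, only, none or still open, it means among the compounds named here.

Compound 1 `O=C(O)c1cn(C2CC2)c2c(Cl)c(N3CCCC3)c(F)cc2c1=O` gives 150 ug/mL in a functional assay on V79 cells (Cricetulus griseus) for cytotoxicity, read by colony formation; a lower number here means a stronger inhibitor, a higher number a weaker inhibitor.
Compound 2 `COc1c(N2CCCC2)c(F)cc2c(=O)c(C(=O)O)cn(C3CC3)c12` gives 150 ug/mL in this assay.
Compound 3 `O=C(O)c1cn(C2CC2)c2c(Cl)c(N3CCNCC3)c(F)cc2c1=O` gives 43 ug/mL in this assay.

Compound 4 `COc1c(N2CCNCC2)c(F)cc2c(=O)c(C(=O)O)cn(C3CC3)c12` has not yet been measured. It is made from compound 3 by one change, (methoxy in place of chloro on an aromatic carbon). The same change is already known between two measured compounds: compound 2 comes from compound 1 by methoxy in place of chloro on an aromatic carbon, and that step gave no change at the digits printed from compound 1 to compound 2 (within the scatter). The two settings are not identical, though: in compound 1 the replaced chloro is ortho to a pyrrolidin-1-yl group, while in compound 3 it is ortho to a piperazin-1-yl group, so the change is of the same kind rather than the same. The cores themselves differ by piperazin-1-yl in place of pyrrolidin-1-yl on an aromatic carbon, a change that gave a 3.5-fold lower number from compound 1 to compound 3 (0.54 log units; beyond the scatter).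

Since the chloro to methoxy swap left compound 1 unchanged, the step from compound 3 to compound 4 is also expected to be small, no change at the digits printed from compound 3 to compound 4 (within the scatter). Compound 4 is therefore estimated at 43 ug/mL, with a likely range from 20 ug/mL to 90 ug/mL.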

Compound 4, half-maximal inhibitory concentration: 82 ug/mL
Compound 4: middle estimate off by 1.9-fold (0.28 log units), on the low side; measured number inside the range.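

In this assay, methoxy in place of chloro on the piperazin-1-yl compounds gave a 1.9-fold higher number from compound 3 to compound 4 (0.28 log units; within the scatter), and this step can be set beside the same swap on the pyrrolidin-1-yl compounds: the same change on two cores in this assay, no change at the digits printed (within the scatter) from compound 1 to compound 2 and a 1.9-fold higher number (0.28 log units; within the scatter) from compound 3 to compound 4, 1.9-fold (0.28 log units) apart, within the scatter of two such steps. Piperazin-1-yl in place of pyrrolidin-1-yl, with methoxy on the ring rather than chloro, gave a 1.8-fold lower number from compound 2 to compound 4 (0.26 log units; within the scatter), and this step too can be compared with its earlier counterpart: the same change on two cores in this assay, a 3.5-fold lower number (0.54 log units; beyond the scatter) from compound 1 to compound 3 and a 1.8-fold lower number (0.26 log units; within the scatter) from compound 2 to compound 4, 1.9-fold (0.28 log units) apart, within the scatter of two such steps. Together these comparisons show that, across these four compounds, neither change behaved measurably differently on the second core, although they rest on only two pairs per change and do not show that the same would hold on any other core.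

The compounds shown leave open whether a bromo or methyl group in place of the chloro would fit the same picture. They also leave open what a morpholin-4-yl group or an open-chain amine would do in place of the piperazin-1-yl group.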